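Swapping the Sulfonyl Aryl Group of a Stable Sulfonamide

The source may report more compounds than this note shows. Statements on the series, on what has been measured and on what is new or still open speak of the compounds shown alone.

The three compounds measured so far:
compound 1 `Cc1ccc(F)cc1S(=O)(=O)N1CCN(c2ccc(C(=O)NCc3ccc(F)cc3)nn2)CC1`: 1.13 h
compound 2 `O=C(NCc1ccccc1)c1ccc(N2CCN(S(=O)(=O)c3cccc(Cl)c3Cl)CC2)nn1`: 0.233 h
compound 3 `O=C(NCc1ccccc1)c1ccc(N2CCC(S(=O)(=O)c3cccc(Cl)c3Cl)CC2)nn1`: 0.333 h

In an ADME assay on microsomes from liver (Mus musculus) for metabolic stability, read by LC-MS, using NADPH, tested at 10 uM (a higher number here means that the compound lasts longer, a lower number that the compound disappears faster), compound 1 stands highest of the three. Compound 3 comes nearest with 0.333 h, and compound 2 lies furthest with 0.233 h; both gaps are beyond the usual scatter. Compound 4 `N#Cc1ncccc1S(=O)(=O)N1CCN(c2ccc(C(=O)NCc3ccc(F)cc3)nn2)CC1` differs from compound 1 in one place: 2-cyanopyridin-3-yl in place of 5-fluoro-2-methylphenyl on a sulfonyl sulfur. For the measured compounds named here, no measured pair shows this same change, so there is no direct guide to its effect. For compound 4 a modest downward step from compound 1 is expected, a 1.6-fold lower number from compound 1 to compound 4 (0.21 log units; within the scatter), with a wide range in both directions. The half-life of compound 4 in this assay is therefore estimated at 0.7 h, between 0.3 h and 1.6 h.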

Compound 4, half-life: 0.0833 h
Beside the measured number, compound 4's estimate is 8.4-fold (0.92 log units) above it, outside the stated range (below it).
By their numbers in this assay, from the lowest: compound 4; then compounds 2 and 3 (each within the scatter of the next); then compound 1.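

In this assay, the group on the sulfonyl sulfur proves to matter a great deal: with the rest of compound 1 unchanged, 2-cyanopyridin-3-yl in place of 5-fluoro-2-methylphenyl gives a 14-fold lower number from compound 1 to compound 4 (1.13 log units; beyond the scatter) in half-life. For the compounds shown here, this is the first measured pair that isolates this position. Nothing measured here accounts for the drop.

On these data alone, the nitrile and the pyridine ring nitrogen enter together, so it remains open which of them, or whether both together, matters. A 2-cyanophenyl or a plain pyridin-3-yl on the same sulfonyl sulfur would separate the two.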